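Rhodanine acids on a shared core: step to a sulfo chain

The source may report more compounds than this note shows. Statements on the series, on what has been measured and on what is new or still open speak of the compounds shown alone.

Measured so far:
compound 1 `Cc1ccc(CN2C(=O)/C(=C3\SC(=S)N(CCCCC(=O)O)C3=O)c3ccccc32)cc1` — 8%
compound 2 `COc1ccc(/C=C2\SC(=S)N(CCCCCC(=O)O)C2=O)cc1Br` — 8%
compound 3 `CCN1C(=O)/C(=C2\SC(=S)N(CCCCCC(=O)O)C2=O)c2ccccc21` — 6%

In an assay for inhibition of histone acetyltransferase KAT2B (Homo sapiens), read by TR-FRET, with a stated time of 10 min, tested at 50 uM (on this read-out lower numbers stand for less inhibition and higher numbers for more inhibition at the one concentration tested (going by the name of the read-out)), compound 1 gives 8%. Compound 2 stands level with compound 1 at the digits shown in this assay, and compound 3 lies within the usual scatter of both, so the three numbers cannot be put in order; all three sit low on the scale of this read-out. No pair of these compounds differs in a single place, so no single step has been quantified.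

Compound 4 `Cc1ccc(CN2C(=O)/C(=C3\SC(=S)N(CCS(=O)(=O)O)C3=O)c3ccccc32)cc1` is not yet measured. It differs from compound 1 as follows: sulfo in place of 2-carboxyethyl on a saturated chain carbon, two bonds along the chain from an amide-type nitrogen in a ring. Among the compounds with values here, nothing among the measured compounds tells what this change does; all three carry a carboxylic acid chain and none carries a sulfo group. On the numbers shown, the expected step is none beyond the scatter, since compound 1 gives 8% and the other two stay in the same region. Compound 4 is therefore expected to reach about 7% in this assay, within a range from -4% to 20%. The step from compound 1 to compound 4 is estimated as a number 1 percentage points lower from compound 1 to compound 4 (within the scatter).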

Compound 4, a percentage reported as inhibition, at one concentration (the size of the read-out at that concentration, not a potency): < 5%
Compound 4: no number, only a limit; the forecaster's own chance of this, stated with the estimate: 0%; middle value at least 2 percentage points away from the limit.
By their numbers in this assay, from the lowest: compounds 3, 1 and 2 (each within the scatter of the next). At a limit, below all of these: compound 4.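

Within the data shown here, this exchange gives the first single-place comparison: sulfo in place of 2-carboxyethyl, on a saturated chain carbon two bonds along the chain from an amide-type nitrogen in a ring, gives a number at least 3 percentage points lower from compound 1 to compound 4 (that floor lies within the scatter) in this assay. For compound 4 the value < 5% is a limit of the assay and not a number. The change brings no gain in inhibition at this place, and how far compound 4 actually lies under compound 1 cannot be read: the limit of < 5% in this assay, at which 1 of the 4 values shown sits.

The compounds shown leave open what would raise the read-out on the shared core. Also open, from the compounds shown here alone, are a sulfo group on a longer chain, an amine or a primary amide at the chain end, and the same exchange on the cores of compound 2 and compound 3.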